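The source may report more compounds than this note shows. Statements on the series, on what has been measured and on what is new or still open speak of the compounds shown alone.

Measured so far in a functional assay on PANC-1 cells (Homo sapiens) for cytotoxicity, read by MTT assay, with a stated time of 68 h; a higher number here means a weaker inhibitor, a lower number a stronger inhibitor:
- compound 1 `O=C(/C=C/c1cccc(OCc2ccccc2)c1)c1ccc([N+](=O)[O-])cc1`: 25400 nM
- compound 2 `O=C(/C=C/c1cccc(OCc2ccccc2)c1)c1ccc(Cl)c(Cl)c1Cl`: 2400 nM

Compound 1 stands highest of the two numbers in this assay; compound 2 lies nearest to it. For the measured compounds named here, the only measured step is an 11-fold lower number from compound 1 to compound 2 (1.02 log units; beyond the scatter), a large move, and it is the single comparison that bears on the change now in hand, since both replace the same group on the same carbonyl carbon.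

Compound 3 `O=C(/C=C/c1cccc(OCc2ccccc2)c1)c1cccc(Br)c1` differs from compound 1 thus: 3-bromophenyl in place of 4-nitrophenyl on a carbonyl carbon.

Going by the values given here, because the one step of that kind, an 11-fold lower number from compound 1 to compound 2 (1.02 log units; beyond the scatter), ran to a lower number, compound 3 is also expected to land below compound 1, though whether a single bromine on the ring carries as far as the trichloro pattern cannot be judged from these two points, so the expected step is set smaller with a wide range. For compound 3 the expected step is a 3.2-fold lower number from compound 1 to compound 3 (0.50 log units; beyond the scatter). Compound 3 is estimated at 8000 nM, between 3000 nM and 22000 nM.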

Compound 3, half-maximal inhibitory concentration: 6400 nM
Compound 3: middle estimate off by 1.3-fold (0.10 log units), on the high side; the range from low to high includes it.
By their numbers in this assay, from the lowest: compound 2; then compound 3; then compound 1.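

In this assay, 3-bromophenyl in place of 4-nitrophenyl on the carbonyl carbon gives a 4.0-fold lower number from compound 1 to compound 3 (0.60 log units; beyond the scatter), so a lower number at this position does not require the 2,3,4-trichlorophenyl group. The two halogen-bearing rings are also separable from each other, with 3-bromophenyl in place of 2,3,4-trichlorophenyl giving a 2.7-fold higher number from compound 2 to compound 3 (0.43 log units; beyond the scatter), which places three groups in a measured order at this one position. No measurement at hand accounts for this order.

Compound 2 and compound 3 differ at once in the halogen, in its number and in its place on the ring, and these compounds do not separate those changes. Also open, going by these compounds, is where a ring carrying an amine or a carboxylic acid would fall in this order.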